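One Added Chloro Group, Measured Once, Expected Again

The source may hold more compounds than are shown below. What is called first, only, known or untested is meant among the compounds shown, and "the series" means these compounds.

Compound 1, `ClCc1cccc(Cn2cnc3c(Cl)ncnc32)c1`, gives 16200 nM in a functional assay on TK-10 cells (Homo sapiens) for cytotoxicity, read by sulforhodamine B assay, with a stated time of 48 h; a lower number here means a stronger inhibitor of growth, a higher number a weaker inhibitor of growth.
Compound 2, `ClCc1cccc(Cn2cnc3c(Cl)nc(Cl)nc32)c1`, gives 3980 nM in this assay.
Compound 3, `ClCc1ccccc1Cn1cnc2ncnc(Cl)c21`, gives 9540 nM in this assay.

Compound 1 and compound 2 share a core and differ in one place: chloro in place of hydrogen on an aromatic carbon. This single change gives a 4.1-fold lower number from compound 1 to compound 2 (0.61 log units; beyond the scatter), so the compound carrying the extra chloro group needs a clearly smaller concentration to stop the cells from growing.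

Compound 3 has the same atoms as compound 1, joined differently; the difference between the two cores is not broken down here. What the two values show is that compound 3 and compound 1 sit within the usual scatter of each other, while compound 2 lies beyond the scatter from compound 3.

Compound 4, `ClCc1ccccc1Cn1cnc2nc(Cl)nc(Cl)c21`, has not been measured. It differs from compound 3 by chloro in place of hydrogen on an aromatic carbon. The place where the new group enters is described in the same words as for the step from compound 1 to compound 2, so the change is the same one, made now on the core of compound 3. Because the earlier step gave a 4.1-fold lower number from compound 1 to compound 2 (0.61 log units; beyond the scatter), a step of similar size is expected here, though a single prior example leaves room for a smaller or larger effect. The expected step is a 3.8-fold lower number from compound 3 to compound 4 (0.58 log units; beyond the scatter), and compound 4 is estimated at 2500 nM, most likely between 900 nM and 7000 nM.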

Compound 4, concentration for total growth inhibition: 33900 nM
Beside the measured number, compound 4's estimate is 14-fold (1.13 log units) below it; measured number outside the range, above it.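

In this assay, placing the chloro group on the core of compound 3 gives a 3.6-fold higher number from compound 3 to compound 4 (0.55 log units; beyond the scatter), whereas the same change lowers the number on the core of compound 1. The two results run in opposite directions, so this single change cannot be treated as one effect that carries over unchanged between these cores: the same change on two cores in this assay, a 4.1-fold lower number (0.61 log units; beyond the scatter) from compound 1 to compound 2 and a 3.6-fold higher number (0.55 log units; beyond the scatter) from compound 3 to compound 4, 14-fold (1.16 log units) apart, beyond the scatter of two such steps. This shows that in this series the outcome of the change depends on the core that carries it, and that a step measured on one core is not a safe guide to the step on the other; it does not show what in the two cores produces the reversal, and two pairs give no rule for any further core.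

The compounds shown carry only hydrogen or chloro on the aromatic carbon between two ring nitrogen atoms, so it remains open whether an amine or a methoxy group at that place would follow the direction seen on the core of compound 1 or the one seen on the core of compound 3. As far as these compounds go, it also remains open which direction, if either, the same chloro change would take on a third core.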